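A ring amino group added to a weak inhibitor

The compounds below may be only part of what the source reports. "The series", "measured", "known", "first", "only" and "open" are said of these compounds alone.

Compound 1 `c1ccc(COc2ccc(OCCOCCNC3CCCC3)cc2)cc1` is tested in a functional assay on SK-OV-3 cells (Homo sapiens) for inhibition, read by CCK-8 assay, with a stated time of 70 h (a lower number here means a stronger inhibitor, a higher number a weaker inhibitor), where it gives 24800 nM. Among the compounds with a plain number it stands lowest, though its neighbour compound 3 `c1ccc(COc2ccc(OCCOCCNC3CC3)cc2)cc1`, with 47200 nM, sits within the scatter of it. Compound 2 `c1ccc(COc2ccc(OCCOCCOC3CCCC3)cc2)cc1` reaches only the limit of the limit of > 100000 nM in this assay, at which 1 of the 3 values shown sits, recorded as > 100000 nM, so no number is known for it. The measured steps concern the far end of the chain: an at least 4.0-fold higher number from compound 1 to compound 2 (0.60 log units; beyond the scatter), a 1.9-fold higher number from compound 1 to compound 3 (0.28 log units; within the scatter) and an at least 2.1-fold lower number from compound 2 to compound 3 (0.32 log units; beyond the scatter). Compound 4 `Nc1cccc(COc2ccc(OCCOCCNC3CCCC3)cc2)c1` differs from compound 1 elsewhere: amino in place of hydrogen on an aromatic carbon. Within the data shown here, none of the measured steps touches this aromatic ring, so there is no direct guide to how the assay answers such a change, and the expectation rests on compound 1 alone. The step to compound 4 is estimated as a 1.0-fold higher number from compound 1 to compound 4 (0.00 log units; within the scatter), that is, no change beyond the scatter. Compound 4 is therefore expected to give about 25000 nM, within a range of 8000 nM to 80000 nM.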

Compound 4, half-maximal inhibitory concentration: 10800 nM
Compound 4: the middle estimate sits 2.3-fold (0.36 log units) above what was measured; measured number inside the range.
By their numbers in this assay, from the lowest: compound 4; then compounds 1 and 3 (each within the scatter of the next). At a limit, above all of these: compound 2.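

Among these compounds, the benzyl end of the molecule, which none of the earlier steps touched, also responds in this assay: going from benzyl to 3-aminobenzyl gives a 2.3-fold lower number from compound 1 to compound 4 (0.36 log units; beyond the scatter). Among the compounds shown here, the earlier steps covered only the far end of the chain, so this is the first sign that the aromatic ring is a second place where a single small change can shift the number, although the step is modest. Nothing shown here gives a reason for this step.

Going by these compounds, it remains open whether this shift is specific to amino or would also appear with a hydroxyl, a methoxy or an acetamido group on the same carbon, or with amino on another carbon of this ring. On these data alone, it is also open whether 3-aminobenzyl would have the same effect with the cyclopropylamino chain end of compound 3.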